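Amide nitrogen substituents in an EP1 binding series

A few compounds are considered here, and "the series" means these few. Any claim that something is new, unique, unknown or untested is made for them only; others in the source may bear on it.

Measured compounds:
Compound 1 `Cc1cc(C(=O)O)nn1Cc1cc(Cl)cn2nc(C(C)C)cc12`: in an assay on CHO-K1 cells for displacement of a labelled ligand from prostaglandin E2 receptor EP1 subtype (Homo sapiens), read by scintillation counting, with a stated time of 45 min (a higher number here means a weaker inhibitor, a lower number a stronger inhibitor), compound 1 gives > 1000 nM, which is a limit of the assay and not a number.
Compound 2 `Cc1cc(C(N)=O)nn1Cc1cc(Cl)cc2cc(-c3ccccc3)oc12`: in this assay compound 2 gives 5.01 nM.
Compound 3 `Cc1cc(C(=O)NC2CC2)nn1Cc1cc(Cl)cc2cc(-c3ccccc3)oc12`: in this assay compound 3 gives 5.01 nM.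

Compound 2 stands level with compound 3 at the digits shown; the two cannot be told apart within the scatter. Compound 1 has a different shared core and only reaches (the limit of > 1000 nM in this assay, at which 1 of the 3 values shown sits), so it offers no number to compare with and is set aside here.

Compound 4 `Cc1cc(C(=O)NC[C@H]2CCCO2)nn1Cc1cc(Cl)cc2cc(-c3ccccc3)oc12` differs from compound 2 in one place: (oxolan-2-yl)methyl in place of hydrogen on an amide-type nitrogen. Within the data shown here, the one measured step that bears on this position is the step of no change at the digits printed from compound 2 to compound 3 (within the scatter): a cyclopropyl put on the same amide nitrogen left the value where it was. Among the measured compounds shown here, the (oxolan-2-yl)methyl group is not cyclopropyl, so that single step is a guide rather than a rule, but it is the only guide available, and it points to no movement beyond the scatter.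

Compound 4 is therefore expected to give about 6 nM in this assay. The expected range for compound 4 runs from 2 nM to 20 nM. The expected step is then a 1.2-fold higher number from compound 2 to compound 4 (0.08 log units; within the scatter), no change beyond the scatter.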

Compound 4, half-maximal inhibitory concentration: 6.31 nM
The estimate for compound 4 lay 1.1-fold (0.02 log units) below the measured number, and the stated range covers the measured number.
By their numbers in this assay, from the lowest: compounds 2, 3 and 4 (each within the scatter of the next). At a limit, above all of these: compound 1.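

In this assay the step from the unsubstituted amide is a 1.3-fold higher number from compound 2 to compound 4 (0.10 log units; within the scatter) and the step between the two substituted amides is a 1.3-fold higher number from compound 3 to compound 4 (0.10 log units; within the scatter). The earlier compounds shown here offered a single replacement of the amide hydrogen, so a flat result could have been particular to cyclopropyl, whereas hydrogen, cyclopropyl and (oxolan-2-yl)methyl now all give values that cannot be told apart on this amide-type nitrogen. The entering group brings 6 heavy atoms, one five-membered non-aromatic ring, 1 hydrogen-bond acceptor and 1 defined stereocentre, yet the value does not move beyond the scatter, and nothing measured here offers a reason for this.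

The compounds shown leave open whether this flat result would hold for quite different groups on the same nitrogen, such as a phenyl ring or a longer chain ending in an amine. They also leave open how the mirror-image form of the (oxolan-2-yl)methyl group would compare, as only one defined stereocentre arrangement appears here.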